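The source may hold more compounds than are shown below. What is called first, only, known or untested is meant among the compounds shown, and "the series" means these compounds.

Compound 2 `COc1cc2c(Oc3ccc(NC(=O)Nc4ccccc4C(F)(F)F)cc3)ccnc2cc1OCCCCCCC(=O)NO` is a urea whose outer ring bears a 2-(trifluoromethyl)phenyl group. In a functional assay on MCF7 cells (Homo sapiens) for antiproliferative activity, read by MTT assay (a higher number here means a weaker inhibitor, a lower number a stronger inhibitor), compound 2 gives 1080 nM, the second highest of the three numbers in hand. Its nearest neighbour is compound 1 `COc1cc2c(Oc3ccc(NC(=O)Nc4cccc(C)c4)cc3)ccnc2cc1OCCCCCCC(=O)NO`, which in this assay gives 1240 nM; the step of a 1.1-fold lower number from compound 1 to compound 2 (0.06 log units; within the scatter) is within the scatter. Compound 3 `COc1cc2c(Oc3ccc(NC(=O)Nc4ccc(C(F)(F)F)cc4Cl)cc3)ccnc2cc1OCCCCCCC(=O)NO` gives 500 nM, and the step of a 2.2-fold lower number from compound 2 to compound 3 (0.33 log units; beyond the scatter) is modest, as is a 2.5-fold lower number from compound 1 to compound 3 (0.39 log units; beyond the scatter).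

Compound 4 `COc1ccccc1NC(=O)Nc1ccc(Oc2ccnc3cc(OCCCCCCC(=O)NO)c(OC)cc23)cc1` differs from compound 2 in one place: methoxy in place of trifluoromethyl on an aromatic carbon. Among the measured compounds shown here, no measured pair exchanges these two groups, so the three steps bear only loosely on it: one shows that replacing the outer ring as a whole leaves the number within the scatter, the other two that a 2-chloro-4-(trifluoromethyl)phenyl ring lowers it modestly. For compound 4 the expected step is a 1.0-fold higher number from compound 2 to compound 4 (0.01 log units; within the scatter), not beyond the scatter. The estimate for compound 4 is 1100 nM, with a range from 500 nM to 2500 nM.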

Compound 4, half-maximal inhibitory concentration: 6280 nM
Estimate against measurement, compound 4: 5.7-fold (0.76 log units) below, and the stated range ends below it.
By their numbers in this assay, from the lowest: compound 3; then compounds 2 and 1 (each within the scatter of the next); then compound 4.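

Among the first three compounds, the changes on the outer ring left the number in this assay within the scatter or lowered it modestly, but this change at the same ring position, ortho to a large group, shows a clear move the other way: methoxy in place of trifluoromethyl gives a 5.8-fold higher number from compound 2 to compound 4 (0.76 log units; beyond the scatter). Among the compounds shown here, the 2-methoxyphenyl ring also stands apart from the other two outer rings, with a 5.1-fold higher number from compound 1 to compound 4 (0.70 log units; beyond the scatter) and a 13-fold higher number from compound 3 to compound 4 (1.10 log units; beyond the scatter), the last being the only large step in the set, so this ring gives the weakest inhibitor of the four. Nothing measured here explains why this exchange has such an effect.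

As far as these compounds go, it remains open whether a hydroxyl, an ethoxy or a plain hydrogen at this position would behave more like methoxy or like trifluoromethyl. From the compounds shown here alone, it is also open whether methoxy would raise the number as much on the ring carrying the chlorine.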